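The source may hold more compounds than are shown below. What is called first, only, known or untested is meant among the compounds shown, and "the series" means these compounds.

The compounds measured so far:

compound 1 `CCN(CC)S(=O)(=O)c1ccc(S(=O)(=O)N2CCC[C@@H](C(=O)N3CCC(OC)CC3)C2)cc1` gives 140 nM in a functional assay on MIA PaCa-2 cells (Homo sapiens) for inhibition, read by MTT assay, with a stated time of 7 days; a higher number here means a weaker inhibitor, a lower number a stronger inhibitor;
compound 2 `O=C([C@@H]1CCCN(S(=O)(=O)c2ccc(S(=O)(=O)C3COC3)cc2)C1)N1CCC(F)(F)CC1` gives 110 nM;
compound 3 `O=C([C@@H]1CCCN(S(=O)(=O)c2ccc(S(=O)(=O)N3CC[C@H](O)C3)cc2)C1)N1CCC(F)(F)CC1` gives 590 nM.

Among these three numbers compound 1 holds the second highest. Its value and that of compound 2 lie within the scatter of one another, so no order between them can be read; compound 3 sits higher than compound 1 by a margin beyond the scatter. Among the compounds with values here, the one single-point step available, a 5.4-fold higher number from compound 2 to compound 3 (0.73 log units; beyond the scatter), concerns the group on the sulfonyl sulfur, a place that compound 1 and compound 4 share unchanged.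

Compound 4 `CCN(CC)S(=O)(=O)c1ccc(S(=O)(=O)N2CCC[C@@H](C(=O)N3CCS(=O)(=O)CC3)C2)cc1` differs from compound 1 at the amide end: 1,1-dioxothiomorpholin-4-yl in place of 4-methoxypiperidin-1-yl on a carbonyl carbon. Within the data shown here, no measured pair changes anything on that carbonyl carbon, so the step from compound 2 to compound 3 gives no direct guide here. With nothing in the data pointing either way, the author expects a step not beyond the scatter, a 1.4-fold higher number from compound 1 to compound 4 (0.13 log units; within the scatter), and estimates compound 4 at 190 nM, within a range of 60 nM to 600 nM in this assay.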

Compound 4, half-maximal inhibitory concentration: 900 nM
For compound 4 the middle estimate is 4.7-fold (0.68 log units) below the measured one, outside the stated range (above it).
By their numbers in this assay, from the lowest: compounds 2 and 1 (each within the scatter of the next); then compounds 3 and 4 (each within the scatter of the next).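

In this assay, within the data shown here, the change at the carbonyl carbon, 1,1-dioxothiomorpholin-4-yl in place of 4-methoxypiperidin-1-yl, gives a 6.4-fold higher number from compound 1 to compound 4 (0.81 log units; beyond the scatter) and so shows that the number responds to the amide end, a place that no earlier pair had touched. The response comes from an exchange of one six-membered non-aromatic ring for another with the same count of heavy atoms, so ring size and atom count alone do not keep the number in place. The compounds offer no measurement that accounts for this step.

As far as these compounds go, whether the step belongs to the two oxygens on the ring sulfur or to the loss of the methoxy group remains open, and thiomorpholin-4-yl or morpholin-4-yl on the same carbonyl carbon would bear on that. Also open, from the compounds shown here alone, is whether 4-hydroxypiperidin-1-yl or piperidin-1-yl there would stay within the scatter of compound 1.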